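The source may report more compounds than this note shows. Statements on the series, on what has been measured and on what is new or still open speak of the compounds shown alone.

Working notes on the thiosemicarbazone series.

Compound 3 `COc1ccc(/C=N/NC(=S)NC(C)(C)[C@H]2CC=C(C)CC2)cc1` gives 12200 nM in an ADME assay on Vero cells (Chlorocebus sabaeus) for inhibition, read by sulforhodamine B assay, with a stated time of 48 h; a higher number here means a weaker inhibitor of growth, a lower number a stronger inhibitor of growth. Compound 2 `CC1=CC[C@H](C(C)(C)NC(=S)N/N=C/c2ccccc2)CC1` gives 20500 nM in this assay, so the pair sits within the scatter of each other; compound 1 `CC1=CC[C@H](C(C)(C)NC(=S)NN)CC1` gives 49500 nM, beyond the scatter from compound 3. Among the compounds with values here, the only single-change step in the set is a 1.7-fold lower number from compound 2 to compound 3 (0.23 log units; within the scatter), the addition of a methoxy to the aryl ring. Compound 4 `CC1=CC[C@H](C(C)(C)NC(=S)N/N=C/c2cccc(Cl)c2)CC1` differs from compound 3 as follows: 3-chlorophenyl in place of 4-methoxyphenyl on a carbon with a double bond to nitrogen. Within the data shown here, no measured step exchanges one aryl substituent for another, so the step from compound 2 to compound 3 bears only loosely here; the expected movement in this assay is a 1.3-fold higher number from compound 3 to compound 4 (0.12 log units; within the scatter), i.e. none beyond the scatter. Compound 4 is therefore estimated at 16000 nM, in the range 7000 nM to 36000 nM.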

Compound 4, concentration for 50% growth inhibition: 14800 nM
Beside the measured number, compound 4's estimate is 1.1-fold (0.03 log units) above it, and the stated range covers the measured number.
By their numbers in this assay, from the lowest: compounds 3, 4 and 2 (each within the scatter of the next); then compound 1.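

In this assay the exchange of the whole aryl group on a carbon with a double bond to nitrogen gives a 1.2-fold higher number from compound 3 to compound 4 (0.08 log units; within the scatter) and so does not separate 3-chlorophenyl from 4-methoxyphenyl. Chloro in place of hydrogen gives a 1.4-fold lower number from compound 2 to compound 4 (0.14 log units; within the scatter) and, like the methoxy step, stays within the scatter, so neither substituent separates from the unsubstituted phenyl at this place. Nothing available accounts for these aryl groups reading alike.

Going by these compounds, whether an amine or a carboxylic acid on the aryl group would give a step beyond the scatter remains open. Also open, on these data alone, is whether any change to the aryl group alters the number at all.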